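Amide to urea on the shared core: compound 4

The source may hold more compounds than are shown below. What is called first, only, known or untested is meant among the compounds shown, and "the series" means these compounds.

Measured so far:
compound 1 `COc1cc(Cl)cc(-c2nn(-c3cccc(NC(=O)c4cc(C(F)(F)F)cc(C(F)(F)F)c4)c3)cc2-c2ccncc2)c1`: 43.5%
compound 2 `COc1cc(Cl)cc(-c2nn(-c3cccc(NC(=O)c4ccc(Cl)c(Cl)c4)c3)cc2-c2ccncc2)c1`: 59.7%
compound 3 `COc1cc(Cl)cc(-c2nn(-c3cccc(NC(=O)c4cccc(C(F)(F)F)c4)c3)cc2-c2ccncc2)c1`: 39.1%

Of the compounds shown here, three on one core have been tested in a functional assay on A549 cells (Homo sapiens) for inhibition, read by sulforhodamine B assay, with a stated time of 48 h, tested at 10 uM; a higher number here means a weaker effect of the compound at the concentration tested, a lower number a stronger effect. Compound 2 has the highest number of the three, meaning the weakest effect at the concentration tested; compound 1 sits below it, and compound 3 lies furthest, the step of a number 20.6 percentage points lower from compound 2 to compound 3 (beyond the scatter) being beyond the scatter. The step of a number 4.4 percentage points lower from compound 1 to compound 3 (within the scatter) lies within the scatter.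

Compound 4 `COc1cc(Cl)cc(-c2nn(-c3cccc(NC(=O)Nc4ccc(Cl)c(Cl)c4)c3)cc2-c2ccncc2)c1` differs from compound 2 in one place: (3,4-dichlorophenyl)amino in place of 3,4-dichlorophenyl on a carbonyl carbon. Neither measured step bears directly on this change; both concern the substituents on the aromatic ring attached to the carbonyl, not the carbonyl itself. There is therefore no measured basis for expecting a step beyond the scatter from compound 2 to compound 4, and the expected step of a number 1.7 percentage points lower from compound 2 to compound 4 (within the scatter) is small. Compound 4 is estimated to give 58%, with a range from 40% to 76%.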

Compound 4, a percentage reported as activity, at one concentration (the size of the read-out at that concentration, not a potency): 11.4%
Compound 4: the middle estimate sits 46.6 percentage points above what was measured; the measured number lies below the stated range.
By their numbers in this assay, from the lowest: compound 4; then compounds 3 and 1 (each within the scatter of the next); then compound 2.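

In this assay, extending the 3,4-dichlorophenyl group to (3,4-dichlorophenyl)amino on the carbonyl carbon, with the ring itself unchanged, gives a number 48.3 percentage points lower from compound 2 to compound 4 (beyond the scatter) and so turns the amide into a urea. The earlier steps shown here changed only the ring on the carbonyl, and this change to the link reaches further than the ring swap a number 20.6 percentage points lower from compound 2 to compound 3 (beyond the scatter), while the urea also stands clear of an amide with a different ring, a number 27.7 percentage points lower from compound 3 to compound 4 (beyond the scatter). Nothing measured here explains why the extra amino link has this effect.

On these data alone, it remains open whether the same change would carry over to a urea bearing 3-(trifluoromethyl)phenyl. Also open, as far as these compounds go, is whether a thiourea, a carbamate or an N-methyl urea at this carbonyl would behave like compound 4.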